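From 4-chlorophenyl to 4-methoxyphenyl at the assay limit

A few compounds are considered here, and "the series" means these few. Any claim that something is new, unique, unknown or untested is made for them only; others in the source may bear on it.

Values measured in a functional assay on BGC-823 cells (Homo sapiens) for antiproliferative activity, read by MTT assay, with a stated time of 48 h; on this read-out higher numbers stand for weaker inhibition and lower numbers for stronger inhibition:
Compound 1 `S=c1oc(-c2ccc3c(c2)OCCO3)nn1CN1CCN(C(c2ccccc2)c2ccccc2)CC1`: > 50000 nM (a limit)
Compound 2 `S=c1oc(-c2ccc3c(c2)OCCO3)nn1CN1CCN(c2cccc(Cl)c2Cl)CC1`: 22600 nM
Compound 3 `S=c1oc(-c2ccc3c(c2)OCCO3)nn1CN1CCN(c2ccc(Cl)cc2)CC1`: > 50000 nM (a limit)

Compound 3 stands at the limit of > 50000 nM in this assay, at which 2 of the 3 values shown sit, so it has a limit and no number. Compound 4 `COc1ccc(N2CCN(Cn3nc(-c4ccc5c(c4)OCCO5)oc3=S)CC2)cc1` differs from it in one place, (methoxy in place of chloro on an aromatic carbon), with methoxy in place of chloro on an aromatic carbon, para to a large group. Among the measured compounds shown here, the one measured step that bears on this change is an at least 2.2-fold higher number from compound 2 to compound 3 (0.34 log units; beyond the scatter), which also concerns the chlorines on that aromatic ring. That step involves no methoxy, and its size is known only as a bound. Resting on it, a shift beyond the scatter is not expected in this assay, and compound 4 is expected to stay close to the limit seen for compound 3. The expected size of the change is a number no higher from compound 3 to compound 4 (the limit leaves the size open), and this is an estimate only. The estimated value for compound 4 is 50000 nM, expected to lie between 18000 nM and 100000 nM.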

Compound 4, half-maximal inhibitory concentration: 18900 nM
Compound 4: middle estimate off by 2.6-fold (0.42 log units), on the high side; the range from low to high includes it.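

In this assay, methoxy in place of chloro on an aromatic carbon, para to a large group, gives an at least 2.6-fold lower number from compound 3 to compound 4 (0.42 log units; beyond the scatter), which shows that this single change can bring a measurable value where the 4-chlorophenyl compound gave none. As far as these compounds go, compound 3 has only a limit, so the true size of that step stays open: the limit of > 50000 nM in this assay, at which 2 of the 4 values shown sit. The 4-methoxyphenyl and 2,3-dichlorophenyl rings cannot be told apart, with a 1.2-fold lower number from compound 2 to compound 4 (0.08 log units; within the scatter), so a measurable value at this level does not require two chlorines on the ring.

From the compounds shown here alone, whether a hydroxyl, an ethoxy or an amine on the same aromatic carbon would behave like methoxy remains open. So does whether a methoxy on another carbon of that ring would give a similar reading.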